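The compounds below may be only part of what the source reports. "The series", "measured", "known", "first", "only" and "open" are said of these compounds alone.

In a functional assay on MOLT-4 cells (Homo sapiens) for inhibition, read by MTT assay, with a stated time of 72 h (on this read-out lower numbers stand for stronger inhibition and higher numbers for weaker inhibition), two compounds built on one shared core have been measured so far. Compound 1, `COc1cc(NC(C)CCCNC(=O)Nc2cccc(Cl)c2)c2ncccc2c1`, gives 21000 nM, and compound 2, `COc1cc(NC(C)CCCNC(=O)Nc2cccc(O)c2)c2ncccc2c1`, gives 24000 nM. Exchanging chloro for hydroxy on an aromatic carbon yields a 1.1-fold higher number from compound 1 to compound 2 (0.06 log units; within the scatter), so compound 2 stands level with compound 1 and the two cannot be ranked.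

The next compound, compound 3, `COc1cc(NC(C)CCCNC(=O)Nc2ccc(C(F)(F)F)cc2)c2ncccc2c1`, has not yet been measured. Its change from compound 2 is larger than a single exchange on the aromatic carbon: 4-(trifluoromethyl)phenyl in place of 3-hydroxyphenyl on an amide-type nitrogen. The whole 3-hydroxyphenyl is replaced by 4-(trifluoromethyl)phenyl on the amide-type nitrogen. For the measured compounds named here, only one measured step bears on this, and only in part, as it also concerns this aromatic group. With the evidence limited to a 1.1-fold higher number from compound 1 to compound 2 (0.06 log units; within the scatter), no step beyond the scatter is expected in this assay, and no direction can be firmly predicted. Going by the values given here, no compound with trifluoromethyl has been measured, so the range is kept wide.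

The estimate amounts to an expected 1.3-fold lower number from compound 2 to compound 3 (0.12 log units; within the scatter). For compound 3 the expected value is 18000 nM, with an estimated range of 7000 nM to 45000 nM.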

Compound 3, half-maximal inhibitory concentration: 20000 nM
Compound 3: the middle estimate sits 1.1-fold (0.05 log units) below what was measured; measured number inside the range.
By their numbers in this assay, from the lowest: compounds 3, 1 and 2 (each within the scatter of the next).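

In this assay, replacing the whole aromatic group on the amide-type nitrogen gives a 1.2-fold lower number from compound 2 to compound 3 (0.08 log units; within the scatter), and the exchange of 3-chlorophenyl for 4-(trifluoromethyl)phenyl gives a 1.1-fold lower number from compound 1 to compound 3 (0.02 log units; within the scatter). The earlier compounds had shown only a single exchange on an aromatic carbon, whereas these steps show that a change of the whole group, to one with more heavy atoms, also stays within the scatter, so the three compounds cannot be ranked. The 3-hydroxyphenyl group carries 1 hydrogen-bond donor and 1 hydrogen-bond acceptor and the 4-(trifluoromethyl)phenyl group carries 0 of each, yet that difference in these compounds comes with no step beyond the scatter, and nothing available offers an explanation for the flat result.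

What the compounds shown leave open is whether any group at this position can move the number beyond the scatter, for instance an amine or a carboxylic acid on the phenyl ring, or a cyclohexyl group in place of the phenyl ring. They also leave open whether a longer chain in the part shared by all three would change the number in this assay.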